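A few compounds are considered here, and "the series" means these few. Any claim that something is new, unique, unknown or untested is made for them only; others in the source may bear on it.

Measured in an ADME assay on S9 fraction from liver (Rattus norvegicus, strain Sprague-Dawley) for metabolic stability, read by LC-MS, using NADPH, with stated times of 5 min and 60 min, tested at 5 uM; on this read-out higher numbers stand for a more stable compound and lower numbers for a less stable compound:
- compound 1 `COc1cc(C2CN(C(=O)c3cc(OCCCC(C)(C)C(=O)O)ccn3)C2)ccc1OCc1ccc(C2CC2)cc1`: 64%
- compound 2 `CCc1ccc(COc2ccc(C3CN(C(=O)c4cc(COC[C@@H](O)CO)ccn4)C3)cc2OC)cc1`: 13%

Of these two, compound 2 holds the lower number. In this assay compound 1 stands at 64% and compound 2 at 13%, a gap beyond the usual scatter.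

The next compound to be tested is compound 3 `CCc1ccc(COc2ccc(C3CN(C(=O)c4cc(COCC(CO)(CO)CO)ccn4)C3)cc2OC)cc1`. It keeps the structure of compound 2 except for one change: 2-hydroxy-1,1-bis(hydroxymethyl)ethyl in place of 1,2-dihydroxyethyl on a saturated chain carbon bound to an oxygen on a saturated carbon. In words, a 2-hydroxy-1,1-bis(hydroxymethyl)ethyl group takes the place of the 1,2-dihydroxyethyl group, on a saturated chain carbon bound to an oxygen on a saturated carbon.

Among the measured compounds shown here, no two measured compounds differ in only one place, so the data offer no measured size for such a change. The rest of the structure stays the same, so the expectation starts from compound 2 at 13%. A small upward move is expected, and it would probably stay within the scatter, as the estimated step of a number 5 percentage points higher from compound 2 to compound 3 (within the scatter) shows. For compound 3 the estimated value is 18%, with an expected range of 6% to 38%.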

Compound 3, percent of the compound remaining: 58%
The estimate for compound 3 lay 40 percentage points below the measured number, outside the stated range (above it).
By their numbers in this assay, from the lowest: compound 2; then compounds 3 and 1 (each within the scatter of the next).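

This pair gives the first measured size for a single change in the series: in this assay, putting 2-hydroxy-1,1-bis(hydroxymethyl)ethyl in place of 1,2-dihydroxyethyl, on a saturated chain carbon bound to an oxygen on a saturated carbon, gives a number 45 percentage points higher from compound 2 to compound 3 (beyond the scatter). It shows that this place in the structure is not indifferent to the group it carries, since the read-out moves this far with the rest of the structure unchanged and both groups being uncharged and free of rings. The change alters several things at once, going from 4 to 7 heavy atoms, from 2 to 3 hydrogen-bond donors and from 1 defined stereocentre to none, and nothing available here links the step to any one of these.

A single pair leaves open which of these differences carries the step, and whether a simple methoxy ether, an amine or a carboxylic acid on the same chain would behave alike. It also leaves open whether the same exchange would give a step of similar size on a core bearing a cyclopropyl group in place of the ethyl group.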